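The source may report more compounds than this note shows. Statements on the series, on what has been measured and on what is new or still open speak of the compounds shown alone.

Compound 1 `CCC(=O)N(c1ccc(OC)cc1)C1CCCC1N(C)C`: 20 mg/kg; 20 mg/kg (2 entries)
Compound 2 `CCC(=O)N(c1ccc([N+](=O)[O-])cc1)C1CCCC1N(C)C`: 6 mg/kg

In a functional assay on the whole organism for antagonist activity, with Mus musculus as the target (a lower number here means that less compound is needed, a higher number that more compound is needed for the effect), compound 2 needs 6 mg/kg, a smaller dose than compound 1 at 20 mg/kg; 20 mg/kg (2 entries). Compound 3 `CCC(=O)N(c1ccc(C(=O)OC)cc1)C1CCCC1N(C)C` keeps the shared core but carries methoxycarbonyl in place of nitro on an aromatic carbon, para to a large group (methoxycarbonyl in place of nitro on an aromatic carbon). Within the data shown here, no measured pair here shows a single change, so the expectation rests only on these two values. The expected change is a 1.7-fold higher number from compound 2 to compound 3 (0.22 log units; within the scatter), a slight rise in dose that stays within the usual scatter. For compound 3 the estimated dose is 10 mg/kg, with an expected range of 4 mg/kg to 25 mg/kg.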

Compound 3, dose for half-maximal effect: > 50 mg/kg
Compound 3 ended at the assay's limit; the forecaster's own chance of this, stated with the estimate: 5%; middle value at least 5.0-fold (0.69 log units) away from the limit.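

In this assay, this position proves sensitive to the group it carries: methoxycarbonyl in place of nitro gives an at least 8.3-fold higher number from compound 2 to compound 3 (0.92 log units; beyond the scatter). The two groups match in hydrogen-bond donors, hydrogen-bond acceptors and net charge, yet they do not behave alike here. The result for compound 3 is a limit and not a number, so the full size of the step stays unknown: the limit of > 50 mg/kg in this assay, at which 1 of the 3 values shown sits.

The compounds shown leave open which feature of methoxycarbonyl matters. A nitrile or a carboxylic acid on this aromatic carbon would help to separate the possibilities.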